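Cytotoxicity Limits for Three Benzyl Variants of One Core

The compounds below may be only part of what the source reports. "The series", "measured", "known", "first", "only" and "open" are said of these compounds alone.

Compound 1 `N#Cc1ccccc1CN1c2ccsc2C(=O)N(Cc2ccccc2)S1(=O)=O` gives > 305000 nM in an ADME assay on MT4 cells (Homo sapiens) for cytotoxicity, read by MTT assay, with a stated time of 4 days; a higher number here means that more compound is tolerated, a lower number that less compound is tolerated.
Compound 2 `N#Cc1cccc(CN2c3ccsc3C(=O)N(Cc3ccccc3)S2(=O)=O)c1` gives > 305000 nM in this assay.

For compound 1 this value is a limit of the assay, not a number. For compound 2 the value is likewise a limit of the assay, so compound 2 stands at the edge of what this assay can report, where the limit of > 305000 nM in this assay, at which 2 of the 2 values shown sit, places both measured compounds. Among the measured compounds shown here, the only measured step, a step that the two limits leave unreadable from compound 1 to compound 2, is therefore unreadable in size and direction.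

Compound 3 `O=C1c2sccc2N(Cc2ccc(Br)cc2)S(=O)(=O)N1Cc1ccccc1` is not yet measured. Its change from compound 2 is 4-bromophenyl in place of 3-cyanophenyl on a saturated chain carbon bound to a sulfonamide nitrogen in a ring. For the measured compounds named here, no measured step bears on this swap, and the one step available gives no size. Compound 3 is expected to stay near the same limit, an estimated step of an at least 1.2-fold lower number from compound 2 to compound 3 (0.08 log units; that floor lies within the scatter), with a chance that a number below the limit appears. The estimate for compound 3 is 250000 nM, ranging from 60000 nM to 305000 nM.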

Compound 3, half-maximal cytotoxic concentration: 6600 nM
Compound 3: middle estimate off by 38-fold (1.58 log units), on the high side, outside the stated range (below it).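

Placing 4-bromophenyl at this position gives the first readable number in this assay, with an at least 46-fold lower number from compound 2 to compound 3 (1.66 log units; beyond the scatter), and the comparison with the other nitrile gives an at least 46-fold lower number from compound 1 to compound 3 (1.66 log units; beyond the scatter). The group on this chain carbon can therefore change how much compound the cells tolerate, which the two cyanophenyl compounds alone could not show. Both steps are minimum sizes, not exact ones, since each starts from a limit of the assay: the limit of > 305000 nM in this assay, at which 2 of the 3 values shown sit.

The swap changes both the substituent and its numbered place on the phenyl ring, so the compounds shown cannot separate the bromine from its place. A 3-bromophenyl or 4-cyanophenyl group would separate the two, and 4-chlorophenyl or 4-aminophenyl would test whether the low number is specific to bromine.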